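This account rests on a few compounds, and the source may have more. Where it says the series, first, only, none or still open, it means among the compounds named here.

Working notes on the series around compound 1 `CC(C)C[C@H](N)CN(C(=O)[C@@H]1C[C@H]1c1ccccc1)c1ccc(-c2ccccc2)cc1`. Going by the values given here, in a functional assay for agonist activity at G protein-coupled receptor 88 (Homo sapiens), read by HTRF and cAMP accumulation (a lower number here means that less compound is needed, a higher number that more compound is needed for the effect), compound 1 gives 880 nM, the highest of the two numbers read so far. Compound 2 `CC(C)C[C@H](N)CN(C(=O)C(C)Cc1ccccc1)c1ccc(-c2ccccc2)cc1` gives 1.2 nM in this assay, and the step of a 730-fold lower number from compound 1 to compound 2 (2.87 log units; beyond the scatter) is the only one in the set that is sized. Compound 3 `CC(C)CCCN(C(=O)[C@@H]1C[C@H]1c1ccccc1)c1ccc(-c2ccccc2)cc1` gives > 100 nM in this assay, which is a limit and not a number. One of the three values therefore sits at the limit of > 100 nM in this assay, at which 1 of the 3 values shown sits, and the step that the limit leaves unreadable from compound 1 to compound 3 cannot be sized.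

Compound 4 `CC(C)C[C@@H](N)CN(C(=O)[C@@H]1C[C@H]1c1ccccc1)c1ccc(-c2ccccc2)cc1` is the next compound to be read in this assay. (the two compounds have the same atoms and bonds and differ only in configuration as drawn: 1 of 3 stereo elements differ; a stereocentre at a saturated chain carbon is drawn S in compound 1 and R in compound 4). Among the compounds with values here, no measured step alters configuration alone, so neither of the two steps bears directly on it. The step from compound 1 to compound 3 removes the amino group from a saturated chain carbon, the same kind of carbon at which compound 1 and compound 4 differ, and that step ran beyond the limit; the step from compound 1 to compound 2 changes the group on the carbonyl carbon and does not touch the amine. A step beyond the scatter in this assay is expected, with a higher number the working assumption. The expected step is a 2.8-fold higher number from compound 1 to compound 4 (0.45 log units; beyond the scatter). Compound 4 is estimated at 2500 nM, between 500 nM and 12000 nM.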

Compound 4, half-maximal effective concentration: 1.8 nM
For compound 4 the middle estimate is 1400-fold (3.14 log units) above the measured one, outside the stated range (below it).
By their numbers in this assay, from the lowest: compounds 2 and 4 (each within the scatter of the next); then compound 1.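

In this assay, the configuration at the saturated chain carbon carrying the amino group is now shown to matter on its own, a point the earlier compounds could not address, and the step of a 490-fold lower number from compound 1 to compound 4 (2.69 log units; beyond the scatter) is large and beyond the scatter with nothing entering or leaving: the fact that compounds 1 and 4 differ only in the configuration as drawn. The value of compound 3 remains a limit, not a number: the limit of > 100 nM in this assay, at which 1 of the 4 values shown sits. With this carbon drawn R, the amino group can now be tied to a step of readable size, an at least 55-fold lower number from compound 3 to compound 4 (1.74 log units; beyond the scatter), while the corresponding step with this carbon drawn S cannot be read.

The compounds shown leave open whether inverting this carbon from S to R has any comparable effect when 1-benzylethyl replaces 2-phenylcyclopropyl on the carbonyl carbon, as the series holds that group only with the S drawing in compound 2. They also leave open how a dimethylamino or hydroxyl group in place of amino would read with this carbon drawn R, and so how much of the amino group's contribution is specific to that group.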